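This account rests on a few compounds, and the source may have more. Where it says the series, first, only, none or still open, it means among the compounds named here.

Series notes. Compound 1 `CC(c1c(F)cc2ncccc2c1F)n1cnc2ncc(-c3cnn(CCO)c3)nc21` carries a 1-(2-hydroxyethyl)-1H-pyrazol-4-yl group on its core; in a functional assay on NCI-H1993 cells (Homo sapiens) for inhibition, read by CCK-8 assay, with a stated time of 72 h (a higher number here means a weaker inhibitor, a lower number a stronger inhibitor), compound 1 gives 83.7 nM. Compound 3 `CC(c1c(F)cc2ncccc2c1F)n1cnc2ncc(-c3ccncc3)nc21` differs from compound 1 by pyridin-4-yl in place of 1-(2-hydroxyethyl)-1H-pyrazol-4-yl on an aromatic carbon, and in this assay compound 3 gives 162 nM, so that a 1.9-fold higher number from compound 1 to compound 3 (0.29 log units; within the scatter). Compound 2 `Cc1c(C(C)n2cnc3ncc(-c4cnn(CCO)c4)nc32)ccc2ncccc12` stands on a different core; how the core of compound 2 differs from the core of compound 1 is not broken down here. In this assay compound 2 gives 726 nM, the highest number of the three, and its gaps to compound 3 and to compound 1 are both beyond the scatter. Compound 4 `Cc1c(C(C)n2cnc3ncc(-c4ccncc4)nc32)ccc2ncccc12` has not yet been measured; it is related to compound 2 by pyridin-4-yl in place of 1-(2-hydroxyethyl)-1H-pyrazol-4-yl on an aromatic carbon, and the change and its place read the same in every word as the change from compound 1 to compound 3, so it is taken as the same change on the other core. The step of a 1.8-fold higher number from compound 2 to compound 4 (0.25 log units; within the scatter) is the expected size, resting on a 1.9-fold higher number from compound 1 to compound 3 (0.29 log units; within the scatter). The number for compound 4 in this assay is expected near 1300 nM, with a likely range from 550 nM to 3500 nM.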

Compound 4, half-maximal inhibitory concentration: 950 nM
For compound 4 the middle estimate is 1.4-fold (0.14 log units) above the measured one, within the range that was stated.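

In this assay pyridin-4-yl in place of 1-(2-hydroxyethyl)-1H-pyrazol-4-yl gives a 1.3-fold higher number from compound 2 to compound 4 (0.12 log units; within the scatter) and, set beside the earlier step, the two cores agree: the same change on two cores in this assay, a 1.9-fold higher number (0.29 log units; within the scatter) from compound 1 to compound 3 and a 1.3-fold higher number (0.12 log units; within the scatter) from compound 2 to compound 4, 1.5-fold (0.17 log units) apart, within the scatter of two such steps.
On these two cores the change therefore carries over with no difference that can be read, and neither step separates the two groups beyond the scatter. Among the compounds shown here, this shows only that the exchange is small on both cores in this one cell assay, on two pairs of compounds; it does not show that the step would hold on any other core, or in any other assay.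

The compounds shown leave open how other groups on this aromatic carbon would read on either core, for example a morpholine, a carboxylic acid or a longer chain than the 2-hydroxyethyl one on the pyrazole. Also open, going by these compounds, is whether any such group would give a step beyond the scatter on one core but not on the other.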